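Amide aryl swap on the phthalimide-bearing anilide core

This account rests on a few compounds, and the source may have more. Where it says the series, first, only, none or still open, it means among the compounds named here.

Measured so far:
compound 1 `O=C(Nc1ccc(Cl)cc1CN1C(=O)c2ccccc2C1=O)c1ccccc1[N+](=O)[O-]`, 5700 nM
compound 2 `O=C(Nc1ccc(Br)cc1CN1C(=O)c2ccc(F)cc2C1=O)c1ccccn1`, 930 nM

In an assay on CHO cells for positive allosteric modulation of metabotropic glutamate receptor 5 (Homo sapiens), read by FLIPR (on this read-out higher numbers stand for an effect only at larger amounts of compound and lower numbers for an effect already at smaller amounts), compound 1 gives 5700 nM, the highest of the two numbers; compound 2 sits lower at 930 nM, a gap beyond the usual scatter. Going by the values given here, no one-point step between measured compounds exists, so nothing measured fixes the size of any single change. Compound 3 `O=C(Nc1ccc(Cl)cc1CN1C(=O)c2ccccc2C1=O)c1ncccn1` differs from compound 1 by pyrimidin-2-yl in place of 2-nitrophenyl on a carbonyl carbon. Given only that compound 2 reaches 930 nM with a different amide aryl group, a modest move downward is expected for compound 3, a 3.2-fold lower number from compound 1 to compound 3 (0.50 log units; beyond the scatter). The estimate for compound 3 is 1800 nM, between 500 nM and 6000 nM.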

Compound 3, half-maximal effective concentration: 2100 nM
Compound 3: middle estimate off by 1.2-fold (0.07 log units), on the low side, and the stated range covers the measured number.
By their numbers in this assay, from the lowest: compound 2; then compound 3; then compound 1.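

Pyrimidin-2-yl in place of 2-nitrophenyl on a carbonyl carbon gives a 2.7-fold lower number from compound 1 to compound 3 (0.43 log units; beyond the scatter) in this assay and is the first single change in the series with a measured size. The nitro-bearing carbon ring is therefore not needed at this place, and a six-membered aromatic ring with 2 hetero atoms keeps a measurable effect. Nothing at hand accounts for the step.

On these data alone, whether plain phenyl or a saturated cyclohexyl ring on the same carbonyl carbon would give a lower or higher number stays open. As far as these compounds go, the separate shares of the bromine and fluorine in compound 2 also stay open.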